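Swapping a Triazole Arm for a Chlorostyryl Group

A few compounds are considered here, and "the series" means these few. Any claim that something is new, unique, unknown or untested is made for them only; others in the source may bear on it.

Of the compounds shown here, three sharing one core have been measured in a functional assay on MCF7 cells (Homo sapiens) for cytotoxicity, read by MTT assay, with a stated time of 72 h; on this read-out higher numbers stand for weaker inhibition and lower numbers for stronger inhibition. Compound 1 `NS(=O)(=O)c1cc(-c2nnc(CN3CCN(c4ccccc4)CC3)o2)c(Cl)cc1SCc1ccccc1` gives 295000 nM. Compound 2 `CC(C)(O)c1cn(Cc2nnc(-c3cc(S(N)(=O)=O)c(SCc4ccccc4)cc3Cl)o2)nn1` gives 168000 nM, the lowest of the three numbers, while compound 3 `COc1ccc(-c2cn(Cc3nnc(-c4cc(S(N)(=O)=O)c(SCc5ccccc5)cc4Cl)o3)nn2)cc1` gives 1500000 nM. The step from compound 1 to compound 2 was a 1.8-fold lower number from compound 1 to compound 2 (0.24 log units; within the scatter), so those two cannot be told apart, whereas the step from compound 2 to compound 3 was an 8.9-fold higher number from compound 2 to compound 3 (0.95 log units; beyond the scatter).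

Compound 4 `NS(=O)(=O)c1cc(-c2nnc(/C=C/c3cccc(Cl)c3)o2)c(Cl)cc1SCc1ccccc1` is the untested member. Relative to compound 2 the change is 2-(3-chlorophenyl)ethenyl in place of (4-(1-hydroxy-1-methylethyl)-1H-1,2,3-triazol-1-yl)methyl on an aromatic carbon. Within the data shown here, no measured step exchanges the whole arm for a group of this kind; the closest information is that compound 1 and compound 2 carry quite different arms and still sit within the scatter of each other, while compound 3 shows that enlarging the arm can weaken the compound. The step from compound 2 to compound 4 is therefore expected to be a 1.5-fold higher number from compound 2 to compound 4 (0.17 log units; within the scatter), with wide uncertainty. Compound 4 is estimated at 250000 nM in this assay, within a range from 80000 nM to 800000 nM.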

Compound 4, half-maximal inhibitory concentration: 11000 nM
Estimate against measurement, compound 4: 23-fold (1.36 log units) above; measured number below the stated range.
By their numbers in this assay, from the lowest: compound 4; then compounds 2 and 1 (each within the scatter of the next); then compound 3.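

This position on the shared core proves far more sensitive than the first steps suggested, when the quite different arms of compound 1 and compound 2 stayed within the scatter of each other. In this assay, putting 2-(3-chlorophenyl)ethenyl in place of (4-(1-hydroxy-1-methylethyl)-1H-1,2,3-triazol-1-yl)methyl gives a 15-fold lower number from compound 2 to compound 4 (1.18 log units; beyond the scatter), although the two arms are close in heavy-atom count. Nothing available here explains why this exchange has so large an effect.

From the compounds shown here alone, the exchange changes several things at once, so it remains open whether the chlorine, the double bond or the loss of the triazole matters most. A 2-phenylethenyl arm without the chlorine and a 2-(3-chlorophenyl)ethyl arm with a saturated chain would begin to separate these.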